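The source may report more compounds than this note shows. Statements on the series, on what has been measured and on what is new or still open speak of the compounds shown alone.

Of the compounds shown here, two of one shared core have been tested in an assay on CHO cells for displacement of a labelled ligand from adenosine receptor A3 (Homo sapiens), read by scintillation counting, with a stated time of 45 min, tested at 1 uM, in the presence of a further agent that is not named here; a lower number here means less inhibition, a higher number more inhibition at the concentration tested (going by the name of the read-out). Compound 1 `CCCn1c(=O)[nH]c2nc(-c3ccc(S(=O)(=O)N4CCN(c5ccccc5Br)CC4)cc3)[nH]c2c1=O` gives 20% in this assay. Compound 2 `CCCn1c(=O)c2[nH]c(-c3ccc(S(=O)(=O)N4CCN(c5ccc(Cl)cc5)CC4)cc3)nc2n(CC)c1=O` gives 28% in this assay; of the two numbers it is the one reported at the greater figure, yet its distance from compound 1 lies within the usual scatter, so the two compounds cannot be told apart on these data. Within the data shown here, no step between compounds that differ in a single place is available.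

Compound 3 `CCCn1c(=O)c2[nH]c(-c3ccc(S(=O)(=O)N4CCN(c5ccc(Cl)cc5)CC4)cc3)nc2n(C)c1=O` has not yet been measured in this assay. It differs from compound 2 by hydrogen in place of methyl on a saturated chain carbon bound to an aromatic nitrogen, which, cut one bond further out, reads ethyl to methyl. Since nothing in the measured pair addresses such a change, the account can only state an expectation: a small step, if any, from compound 2 to compound 3, not beyond the scatter and with no strong lean in either direction, perhaps a slight fall. Compound 3 is therefore expected to give 25% in this assay, within a range from 10% to 40%, which amounts to an expected step of a number 3 percentage points lower from compound 2 to compound 3 (within the scatter).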

Compound 3, a percentage reported as inhibition, at one concentration (the size of the read-out at that concentration, not a potency): 39%
For compound 3 the middle estimate is 14 percentage points below the measured one, and the stated range covers the measured number.
By their numbers in this assay, from the lowest: compounds 1 and 2 (each within the scatter of the next); then compound 3.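

Among these compounds, the change of methyl to hydrogen on a saturated chain carbon bound to an aromatic nitrogen, which reads ethyl to methyl when cut one bond further out, gives the first comparison of compounds differing in one place in this assay, with a number 11 percentage points higher from compound 2 to compound 3 (beyond the scatter). This shows that the position is not silent in this read-out: the loss of one carbon, with no ring, no hydrogen-bond donor or acceptor and no net charge involved, gives a modest step beyond the scatter, and the shorter chain is the one with more inhibition at the concentration tested. No measurement at hand accounts for this step.

One pair cannot show whether the figure depends on chain length in any regular way, or what a propyl chain, or a chain ending in an amine or a carboxylic acid, would give at this place. Going by these compounds, the figures are also readings at a single concentration, so it remains open whether the step would carry over to a measured potency.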